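The compounds below may be only part of what the source reports. "The series", "measured", "known", "first", "only" and "open" are said of these compounds alone.

The measured compounds:
Compound 1, `CC(C)(C)c1ccc(C(C)(C)NC(=O)c2ccc([N+](=O)[O-])o2)cc1`: in an ADME assay on Vero cells (Chlorocebus sabaeus) for cytotoxicity, read by MTT assay, with a stated time of 48 h (a lower number here means that less compound is tolerated, a higher number that more compound is tolerated), compound 1 gives > 150000 nM, a limit of the assay.
Compound 2, `CC(C)(NC(=O)c1ccc([N+](=O)[O-])o1)c1ccc(OC(F)(F)F)cc1`: in this assay compound 2 gives 70000 nM.
Compound 3, `CC(C)(NC(=O)c1ccc([N+](=O)[O-])o1)c1ccc(-c2ccc(Cl)cc2)cc1`: in this assay compound 3 gives > 140000 nM, which is also a limit of the assay.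

Compound 3 thus stands at a limit rather than at a number, and one further value shown is likewise a limit (the limit of > 150000 nM in this assay, at which 1 of the 3 values shown sits). From compound 2 the step is an at least 2.0-fold higher number from compound 2 to compound 3 (0.30 log units; that floor lies within the scatter), while a step that the two limits leave unreadable from compound 1 to compound 3. Compound 4, `CC(C)(NC(=O)c1ccc([N+](=O)[O-])o1)c1ccc(Oc2ccc(Cl)cc2)cc1`, differs from compound 3 in one place: 4-chlorophenoxy in place of 4-chlorophenyl on an aromatic carbon. The step that bears most on this change is an at least 2.0-fold higher number from compound 2 to compound 3 (0.30 log units; that floor lies within the scatter), where one group carrying an oxygen was exchanged for the directly attached 4-chlorophenyl; the reverse direction of that exchange hints at a somewhat lower number, but its floor lies within the scatter. The piece therefore expects an at least 1.4-fold lower number from compound 3 to compound 4 (0.14 log units; that floor lies within the scatter). For compound 4 the estimated value in this assay is 100000 nM, with a range from 40000 nM to 200000 nM.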

Compound 4, half-maximal cytotoxic concentration: 67000 nM
Beside the measured number, compound 4's estimate is 1.5-fold (0.17 log units) above it; measured number inside the range.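

In this assay, the oxygen that turns 4-chlorophenyl into 4-chlorophenoxy is enough for a change beyond the scatter, an at least 2.0-fold lower number from compound 3 to compound 4 (0.32 log units; beyond the scatter), and the comparison with tert-butyl on the same aromatic carbon also gives an at least 2.2-fold lower number from compound 1 to compound 4 (0.35 log units; beyond the scatter). The group on that oxygen matters little here, with trifluoromethyl and 4-chlorophenyl giving a 1.0-fold lower number from compound 2 to compound 4 (0.02 log units; within the scatter), so among these four compounds both groups attached through oxygen give readable numbers, and none goes against this. The step into compound 4 is only a floor, since compound 3 stands at a limit: the limit of > 140000 nM in this assay, at which 1 of the 4 values shown sits.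

The compounds shown leave open whether the oxygen itself counts or whether a sulfur or methylene link to the 4-chlorophenyl ring would behave the same way. Going by these compounds, the true size of the step from compound 3 also stays open.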